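Replacing trifluoromethyl on compound 1 with an imidazole

The source may hold more compounds than are shown below. What is called first, only, known or untested is meant among the compounds shown, and "the series" means these compounds.

In an ADME assay on microsomes (Homo sapiens) for metabolic stability (a lower number here means slower removal, a higher number faster removal of the compound), compound 1 `CNC(=O)[C@@H]1CCCN1S(=O)(=O)c1ccc(Cl)c(COc2cccc3c(C(F)(F)F)cc(C)nc23)c1Cl` gives 250 mL/min/kg. Compound 2 `Cc1cc(C(F)(F)F)c2cccc(OCc3c(Cl)ccc(S(=O)(=O)N4CCC[C@H]4C(N)=O)c3Cl)c2n1` gives 167 mL/min/kg, and compound 3 `Cc1cc(C(F)(F)F)c2cccc(OCc3c(Cl)ccc(S(=O)(=O)N4CCC(CCO)CC4)c3Cl)c2n1` gives 367 mL/min/kg. Compound 1 sits within the scatter of both, as a 1.5-fold lower number from compound 1 to compound 2 (0.18 log units; within the scatter) and a 1.5-fold higher number from compound 1 to compound 3 (0.17 log units; within the scatter) show. Only a 2.2-fold higher number from compound 2 to compound 3 (0.34 log units; beyond the scatter) goes beyond the scatter, and modestly.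

Compound 4 `CNC(=O)[C@@H]1CCCN1S(=O)(=O)c1ccc(Cl)c(COc2cccc3c(-c4nccn4C)cc(C)nc23)c1Cl` has 1-methyl-1H-imidazol-2-yl in place of trifluoromethyl on an aromatic carbon. Among the compounds with values here, all three measured compounds keep the trifluoromethyl, so no measured step tests this swap or gives it a direction. The starting point therefore stays compound 1 at 250 mL/min/kg. The expected change is small, a 1.1-fold lower number from compound 1 to compound 4 (0.06 log units; within the scatter), within the scatter. For compound 4 the estimated clearance is 220 mL/min/kg, with an expected range of 110 mL/min/kg to 420 mL/min/kg.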

Compound 4, clearance: 117 mL/min/kg
The estimate for compound 4 lay 1.9-fold (0.27 log units) above the measured number, within the range that was stated.
By their numbers in this assay, from the lowest: compounds 4, 2, 1 and 3 (each within the scatter of the next, the first and the last beyond it).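

On the carbon opposite the ring nitrogen, the trifluoromethyl group can give way to 1-methyl-1H-imidazol-2-yl, and in this assay this gives a 2.1-fold lower number from compound 1 to compound 4 (0.33 log units; beyond the scatter), a modest change. Among the steps from compound 1, this is the only one beyond the scatter; the changes at the amide nitrogen and the sulfonyl sulfur stay within it. No measurement here explains this step.

From the compounds shown here alone, whether a nitrile or an unsubstituted phenyl ring on this carbon would give a similar number remains open. So does whether the same swap would lower the number on compound 2 or compound 3.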